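Varying the Amide Aryl Group on a Shared Core

The compounds below may be only part of what the source reports. "The series", "measured", "known", "first", "only" and "open" are said of these compounds alone.

Three compounds share one core and differ only in the aryl group attached to the carbonyl carbon of an amide. Compound 1 `O=C(Nc1cccc(-c2oc3cc(-c4ccc(F)cc4)ccc3c(=O)c2O)c1)c1ccc(F)cc1F` carries a 2,4-difluorophenyl there, and in a functional assay on HCC1937 cells (Homo sapiens) for antiproliferative activity, read by CCK-8 assay, with a stated time of 72 h (a higher number here means a weaker inhibitor, a lower number a stronger inhibitor), compound 1 gives 6980 nM. Compound 2 `Cc1ccccc1C(=O)Nc1cccc(-c2oc3cc(-c4ccc(F)cc4)ccc3c(=O)c2O)c1` carries a 2-methylphenyl; in this assay compound 2 gives 9900 nM. Compound 3 `O=C(Nc1cccc(-c2oc3cc(-c4ccc(F)cc4)ccc3c(=O)c2O)c1)c1cccc(F)c1` carries a 3-fluorophenyl, and in this assay compound 3 gives 6590 nM. Compound 3 has the lowest of the three numbers, yet the step of a 1.1-fold lower number from compound 1 to compound 3 (0.02 log units; within the scatter) and the step of a 1.5-fold lower number from compound 2 to compound 3 (0.18 log units; within the scatter) both stay within the scatter, as does the step of a 1.4-fold higher number from compound 1 to compound 2 (0.15 log units; within the scatter), so the three compounds cannot be told apart on these measurements.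

Compound 4 `O=C(Nc1cccc(-c2oc3cc(-c4ccc(F)cc4)ccc3c(=O)c2O)c1)c1ccc(-c2ccccc2)cc1` is the next member of this set, and it differs from compound 3 in one place: 4-phenylphenyl in place of 3-fluorophenyl on a carbonyl carbon. The three measured steps all concern a swap of the aryl group on the carbonyl carbon, and none of them moved the number beyond the scatter. On these data alone, none of them involves a 4-phenylphenyl, so the effect of the second ring is untested. On that basis only a small step is expected, a 1.0-fold lower number from compound 3 to compound 4 (0.01 log units; within the scatter). Compound 4 is therefore estimated at 6500 nM, with a range from 2500 nM to 17000 nM.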

Compound 4, half-maximal inhibitory concentration: 44100 nM
The estimate for compound 4 lay 6.8-fold (0.83 log units) below the measured number; the measured number lies above the stated range.
By their numbers in this assay, from the lowest: compounds 3, 1 and 2 (each within the scatter of the next); then compound 4.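

At this position, on a carbonyl carbon whose other neighbour is an amide-type nitrogen, the aryl group can no longer be treated as freely exchangeable: in this assay the 4-phenylphenyl gives a 6.7-fold higher number from compound 3 to compound 4 (0.83 log units; beyond the scatter), along with a 4.5-fold higher number from compound 2 to compound 4 (0.65 log units; beyond the scatter) and a 6.3-fold higher number from compound 1 to compound 4 (0.80 log units; beyond the scatter), all three beyond the scatter. Compound 4 is the only one of the four with two six-membered aromatic rings in this group, and its change is the only one here that moves the number beyond the scatter, towards a weaker inhibitor, whereas the groups with one ring stay within the scatter of one another. No measurement at hand gives a reason for this loss of activity.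

Compound 4 is the sole example of a second ring at this position, so the compounds shown cannot tell whether any second ring has this effect or only this particular arrangement, and a 3-phenylphenyl would bear on that question. On these data alone, how the number responds to a phenyl ring carrying an amine or a carboxylic acid also remains open.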